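A few compounds are considered here, and "the series" means these few. Any claim that something is new, unique, unknown or untested is made for them only; others in the source may bear on it.

Compound 1 `Clc1ccc2[nH]cc(Cn3ccnc3)c2c1` and compound 2 `O=C(O)CCn1cc(Cn2ccnc2)c2cc(Cl)ccc21` share one core and differ only at the aromatic nitrogen. In an assay for inhibition of Thromboxane-A synthase (Homo sapiens) (on this read-out higher numbers stand for weaker inhibition and lower numbers for stronger inhibition), compound 1 gives 3000 nM, while compound 2 gives 21 nM. Within the data shown here, the single measured step, a 140-fold lower number from compound 1 to compound 2 (2.15 log units; beyond the scatter), is the whole of what is known so far, and it places compound 2 at the lowest of the two numbers in this assay, with compound 1 the only neighbour and far above it.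

Compound 3 `O=C(O)CCn1cc(Cn2ccnc2)c2cc(Br)ccc21` keeps the 2-carboxyethyl group of compound 2 and changes the halogen instead: bromo in place of chloro on an aromatic carbon. Among the measured compounds shown here, no measured step touches that position; the step from compound 1 to compound 2 concerns the aromatic nitrogen and says nothing about exchanging one halogen for another on the six-membered ring of carbon only. With nothing in the data to point either way, an exchange of two halogens of this kind is expected to move the number little, if at all, beyond the scatter. Compound 3 is therefore expected to give about 20 nM in this assay, between 8 nM and 50 nM, a step of a 1.1-fold lower number from compound 2 to compound 3 (0.02 log units; within the scatter) that is estimated to stay within the scatter.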

Compound 3, half-maximal inhibitory concentration: 12 nM
Compound 3: the middle estimate sits 1.7-fold (0.22 log units) above what was measured; the range from low to high includes it.
By their numbers in this assay, from the lowest: compounds 3 and 2 (each within the scatter of the next); then compound 1.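

With the 2-carboxyethyl group held fixed, the exchange of bromo for chloro on an aromatic carbon of the six-membered aromatic ring gives a 1.8-fold lower number from compound 2 to compound 3 (0.24 log units; within the scatter), so this assay does not tell these two halogens apart at this position. This is the first reading from this part of the molecule, and it differs in size from the only other step shown, a 140-fold lower number from compound 1 to compound 2 (2.15 log units; beyond the scatter), which concerns the aromatic nitrogen and lies beyond the scatter. No further measurement accompanies these numbers that could bear on the result at this position.

The compounds shown leave open whether this aromatic carbon would respond the same way to a group other than a halogen, such as hydrogen, methyl, methoxy or an amine, since chloro and bromo are the only groups seen there. They also leave open how much of the step at the aromatic nitrogen depends on the carboxylic acid and on the length of its chain, as an ester, an amide or a longer chain on that nitrogen does not appear among them.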